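Replacing Methylsulfanyl with Hydroxy on an Aromatic Carbon

This account rests on a few compounds, and the source may have more. Where it says the series, first, only, none or still open, it means among the compounds named here.

Three compounds share one core and differ only in a single group on an aromatic carbon. In a functional assay on SK-OV-3 cells (Homo sapiens) for cytotoxicity, read by MTT assay, with a stated time of 48 h (on this read-out lower numbers stand for stronger inhibition and higher numbers for weaker inhibition), compound 1 `O=C(/C=C/c1ccc2c(c1)B(O)OC2)c1ccc(Br)cc1` gives 4500 nM; compound 2 `CCc1ccc(C(=O)/C=C/c2ccc3c(c2)B(O)OC3)cc1` gives 4400 nM; compound 3 `CSc1ccc(C(=O)/C=C/c2ccc3c(c2)B(O)OC3)cc1` gives 4100 nM. Compound 3 carries the smallest of the three numbers, yet the steps of a 1.0-fold lower number from compound 1 to compound 2 (0.01 log units; within the scatter), a 1.1-fold lower number from compound 1 to compound 3 (0.04 log units; within the scatter) and a 1.1-fold lower number from compound 2 to compound 3 (0.03 log units; within the scatter) all stay within the scatter, so the three stand as equals. Compound 4 `O=C(/C=C/c1ccc2c(c1)B(O)OC2)c1ccc(O)cc1` brings (hydroxy in place of methylsulfanyl on an aromatic carbon). Every measured swap at this position left the number essentially unmoved, so for compound 4 the expected step is a 1.1-fold higher number from compound 3 to compound 4 (0.04 log units; within the scatter), none beyond the scatter. Compound 4 is therefore estimated at 4500 nM, within a range from 2000 nM to 10000 nM.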

Compound 4, half-maximal inhibitory concentration: 13000 nM
For compound 4 the middle estimate is 2.9-fold (0.46 log units) below the measured one, outside the stated range (above it).
By their numbers in this assay, from the lowest: compounds 3, 2 and 1 (each within the scatter of the next); then compound 4.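

In this assay this position proved not to be indifferent: bromo, ethyl and methylsulfanyl stood as equals, but hydroxy separates from all three (a 3.2-fold higher number from compound 3 to compound 4 (0.50 log units; beyond the scatter)), (a 3.0-fold higher number from compound 2 to compound 4 (0.47 log units; beyond the scatter)) and (a 2.9-fold higher number from compound 1 to compound 4 (0.46 log units; beyond the scatter)). Each step is modest, yet each lies beyond the scatter and points towards weaker inhibition. No measurement here explains this change. As far as these compounds go, whether an amine or a methoxy group at this place would behave like hydroxy or like the other three remains open, as does whether a carboxylic acid would move the number further.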